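This account rests on a few compounds, and the source may have more. Where it says the series, first, only, none or still open, it means among the compounds named here.

Measured in a functional assay on A549 cells (Homo sapiens) for inhibition, read by sulforhodamine B assay, with a stated time of 72 h; a higher number here means a weaker inhibitor, a lower number a stronger inhibitor:
- Compound 1 `C#Cc1cccc(Nc2ncnc3cc(OCCCCn4ccnc4[N+](=O)[O-])c(OC)cc23)c1`: 2210 nM
- Compound 2 `COc1cc2c(Nc3ccc(OCc4cccc(F)c4)c(Cl)c3)ncnc2cc1OCCCCCCn1ccnc1[N+](=O)[O-]`: > 50000 nM (a limit, not a number)
- Compound 3 `COc1cc2c(Nc3cccc(Br)c3)ncnc2cc1OCCCCn1ccnc1[N+](=O)[O-]`: 3090 nM

Compound 3 stands level with compound 1: the step is a 1.4-fold higher number from compound 1 to compound 3 (0.15 log units; within the scatter), with bromo in place of ethynyl on an aromatic carbon. Compound 4 `COc1cc2c(Nc3cccc(Br)c3)ncnc2cc1OCCCCCCn1ccnc1[N+](=O)[O-]` differs from compound 3 in one place, (2-(2-nitro-1H-imidazol-1-yl)ethyl in place of 2-nitro-1H-imidazol-1-yl on a saturated chain carbon, four bonds along the chain from an oxygen on an aromatic ring). That step was made elsewhere on the molecule, so it says little about this change. Compound 2 shares the chain of compound 4 but differs elsewhere, and it gives only (the limit of > 50000 nM in this assay, at which 1 of the 3 values shown sits). This hints weakly at a higher number. The expected change is a 1.9-fold higher number from compound 3 to compound 4 (0.29 log units; within the scatter), toward a weaker inhibitor. The estimate for compound 4 is 6000 nM, with an expected range of 2000 nM to 30000 nM.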

Compound 4, half-maximal inhibitory concentration: 30200 nM
The estimate for compound 4 lay 5.0-fold (0.70 log units) below the measured number; the whole stated range lies below it.
By their numbers in this assay, from the lowest: compounds 1 and 3 (each within the scatter of the next); then compound 4. At a limit, above all of these: compound 2.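

Lengthening the chain matters at this position: 2-(2-nitro-1H-imidazol-1-yl)ethyl in place of 2-nitro-1H-imidazol-1-yl gives a 9.8-fold higher number from compound 3 to compound 4 (0.99 log units; beyond the scatter), toward a weaker inhibitor. Among these compounds, the only step readable before this one, bromo in place of ethynyl, stayed within the scatter, so the chain is the first place here where a single change clearly moves the number. Compound 2 carries the same chain as compound 4, and its value is a limit, not a number: the limit of > 50000 nM in this assay, at which 1 of the 4 values shown sits.

The compounds shown leave open how a shorter chain would behave at this position. They also leave open whether an amine in place of the nitro group on the imidazole would change the picture.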